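Dichloro Substitution on the Hydroxyphenyl Arm

The source may hold more compounds than are shown below. What is called first, only, known or untested is meant among the compounds shown, and "the series" means these compounds.

Compound 3 `O=C(CSc1nnc(-c2ccncc2)o1)N/N=C/c1ccccc1O` gives the lowest number of the three measured in a functional assay on BGC-823 cells (Homo sapiens) for cytotoxicity, read by MTT assay, with a stated time of 48 h (on this read-out higher numbers stand for weaker inhibition and lower numbers for stronger inhibition), namely 6160 nM. Compound 1 `O=C(CSc1nnc(-c2ccncc2)o1)N/N=C/c1ccc(Br)cc1` gives 24500 nM and compound 2 `COc1cccc(/C=N/NC(=O)CSc2nnc(-c3ccncc3)o2)c1` gives 15800 nM; the steps of a 4.0-fold lower number from compound 1 to compound 3 (0.60 log units; beyond the scatter) and a 2.6-fold lower number from compound 2 to compound 3 (0.41 log units; beyond the scatter) both point toward the 2-hydroxyphenyl arm. Compound 4 `O=C(CSc1nnc(-c2ccncc2)o1)N/N=C/c1cc(Cl)cc(Cl)c1O` differs from compound 3 by 3,5-dichloro-2-hydroxyphenyl in place of 2-hydroxyphenyl on a carbon with a double bond to nitrogen. Within the data shown here, no measured step adds chlorine to this arm; the two steps reaching compound 3 concern the arm itself, which is retained here, so they set no direction for the new change. Going by these compounds, the expected step of a 1.4-fold lower number from compound 3 to compound 4 (0.14 log units; within the scatter) is therefore small, and either direction remains open. Compound 4 is estimated at 4500 nM, within 1500 nM to 14000 nM.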

Compound 4, half-maximal inhibitory concentration: 6340 nM
Estimate against measurement, compound 4: 1.4-fold (0.15 log units) below; measured number inside the range.
By their numbers in this assay, from the lowest: compounds 3 and 4 (each within the scatter of the next); then compounds 2 and 1 (each within the scatter of the next).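

In this assay the two chlorines on the 2-hydroxyphenyl arm leave the number where it was, with a 1.0-fold higher number from compound 3 to compound 4 (0.01 log units; within the scatter) inside the scatter, so this arm tolerates them in this assay. The dichloro arm also keeps the lead of the 2-hydroxyphenyl arm over the other two arms, with a 2.5-fold lower number from compound 2 to compound 4 (0.40 log units; beyond the scatter) and a 3.9-fold lower number from compound 1 to compound 4 (0.59 log units; beyond the scatter) both beyond the scatter. Nothing given here explains this result. Going by these compounds, whether a single chlorine would behave the same remains open, as does the effect of bromine, methyl or an amine in place of the chlorines.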